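Chain extension on the hydroxyalkylthio side chain: compound 3

This account rests on a few compounds, and the source may have more. Where it says the series, first, only, none or still open, it means among the compounds named here.

Compound 1, `CC1=C(SCCCO)C(=O)c2ccccc2C1=O`: in a functional assay on A549 cells (Homo sapiens) for inhibition (a lower number here means a stronger inhibitor, a higher number a weaker inhibitor), compound 1 gives > 10000 nM, a limit of the assay and not a number.
Compound 2, `CC1=C(SCCCCO)C(=O)c2ccccc2C1=O`: in this assay compound 2 gives > 10000 nM, likewise a limit.

Compound 2 therefore stands only at the limit of this assay, with no measured number of its own. Within the data shown here, the one further value shown, for compound 1, is also a limit, so both measured compounds sit at the limit of > 10000 nM in this assay, at which 2 of the 2 values shown sit. The step that the two limits leave unreadable from compound 1 to compound 2 cannot be read from two limits.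

Compound 3, `CC1=C(SCCCCCCO)C(=O)c2ccccc2C1=O`, carries the same kind of change one bond further out: 2-hydroxyethyl in place of hydroxy on a saturated chain carbon, four bonds along the chain from a sulfur. Among the measured compounds shown here, the only measured step of comparable kind, a step that the two limits leave unreadable from compound 1 to compound 2, has no readable size, so neither a direction nor a magnitude can be taken from it for this assay.

Compound 3 is expected to remain at the limit, with an estimate of 20000 nM, between 6000 nM and 60000 nM. That estimate corresponds to an expected step that the limit leaves unreadable from compound 2 to compound 3, meaning no readable change beyond the limit.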

Compound 3, half-maximal inhibitory concentration: > 10000 nM
Compound 3: a limit, no number (the forecaster's own chance of this, stated with the estimate: 85%); the middle value lies beyond the limit too.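

No step can be read among compound 1, compound 2 and compound 3 in this assay, since all three values are limits and not numbers: the limit of > 10000 nM in this assay, at which 3 of the 3 values shown sit. The compounds shown leave open whether any length of the hydroxyalkylthio side chain changes inhibition in this assay.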